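Cytotoxicity of pyrazole analogues: methoxy to hydroxy step

A few compounds are considered here, and "the series" means these few. Any claim that something is new, unique, unknown or untested is made for them only; others in the source may bear on it.

Measured compounds in a functional assay on IGROV-1 cells (Homo sapiens) for cytotoxicity, read by sulforhodamine B assay, with a stated time of 48 h, tested at 100 nM; a higher number here means a weaker effect of the compound at the concentration tested, a lower number a stronger effect:
- compound 1 `COc1cc(C)cc(-c2c(-c3ccnc(-c4ccc(C(C)=O)cc4)c3)cnn2CC#N)c1`: 83%
- compound 2 `Cc1cc(O)cc(-c2nn(CC#N)cc2-c2ccnc(-c3ccc(Oc4ccccc4)cc3)c2)c1`: 86%
- compound 3 `COc1cc(C)cc(-c2nn(CC#N)cc2-c2ccnc(-c3ccc(N(C)C)cc3)c2)c1`: 16%

Compound 3 has the lowest number of the three, meaning the strongest effect at the tested concentration; both other values lie well beyond the scatter above it. Compound 1 and compound 2 are within the scatter of each other. Compound 4 `Cc1cc(O)cc(-c2nn(CC#N)cc2-c2ccnc(-c3ccc(N(C)C)cc3)c2)c1` differs from compound 3 by one change: hydrogen in place of methyl on an oxygen on an aromatic ring. Within the data shown here, no measured pair here isolates this change, so its size is not known from these data. The expected step of a number 14 percentage points higher from compound 3 to compound 4 (beyond the scatter) is a small weakening, within or just beyond the scatter, with compound 4 keeping most of the strong effect seen for compound 3. Compound 4 is therefore estimated at 30%, with a range of 10% to 65%.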

Compound 4, a percentage reported as activity, at one concentration (the size of the read-out at that concentration, not a potency): 87%
Beside the measured number, compound 4's estimate is 57 percentage points below it, and the stated range ends below it.
By their numbers in this assay, from the lowest: compound 3; then compounds 1, 2 and 4 (each within the scatter of the next).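

In this assay, the change from methoxy to hydroxy on the aromatic ring is large, a number 71 percentage points higher from compound 3 to compound 4 (beyond the scatter), so the methyl on this oxygen matters greatly when dimethylamino is present. With hydroxy in place, dimethylamino instead of phenoxy gives a number 1 percentage points higher from compound 2 to compound 4 (within the scatter), so dimethylamino alone does not secure the strong effect seen for compound 3. Nothing available explains this loss of effect. Going by these compounds, whether ethoxy or an amine at this position would keep the effect remains open, as does the size of the methoxy to hydroxy step when phenoxy replaces dimethylamino.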